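A few compounds are considered here, and "the series" means these few. Any claim that something is new, unique, unknown or untested is made for them only; others in the source may bear on it.

Compound 1 `Nc1nc(-c2ccccc2F)cs1`: 6800 nM
Compound 2 `Nc1nc(-c2c(F)cccc2F)cs1`: > 10000 nM
Compound 3 `Nc1nc(-c2ccc(F)c(C(F)(F)F)c2)cs1`: 100 nM

All three were tested in a functional assay for agonist activity at thrombopoietin receptor (Homo sapiens); on this read-out lower numbers stand for an effect already at smaller amounts and higher numbers for an effect only at larger amounts of compound. For compound 2 the value is a limit of the assay, not a number (the limit of > 10000 nM in this assay, at which 1 of the 3 values shown sits). The change fluoro in place of hydrogen on an aromatic carbon gave an at least 1.4-fold higher number from compound 1 to compound 2 (0.16 log units; that floor lies within the scatter). How the core of compound 3 differs from that of compound 1 is not broken down here; compound 3 gives the lowest number of the two measured ones, with compound 1 well above it. Compound 4 `Nc1nc(-c2ccc(F)c(C(F)(F)F)c2)c(F)s1` has not yet been measured. It differs from compound 3 by fluoro in place of hydrogen on an aromatic carbon, the same kind of change as from compound 1 to compound 2, though at a different place: there on a six-membered aromatic ring of carbon only, ortho to a group of 6 heavy atoms and meta to a fluoro group; here on a five-membered aromatic ring with 1 nitrogen and 1 sulfur, next to the ring sulfur. Beside the earlier step, compound 4 is expected to show a 2.0-fold higher number from compound 3 to compound 4 (0.30 log units; within the scatter), a modest weakening resting on the direction of an at least 1.4-fold higher number from compound 1 to compound 2 (0.16 log units; that floor lies within the scatter). Compound 4 is therefore estimated at 200 nM, likely between 60 nM and 700 nM.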

Compound 4, half-maximal effective concentration: 89 nM
Beside the measured number, compound 4's estimate is 2.2-fold (0.35 log units) above it; measured number inside the range.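

In this assay, fluoro in place of hydrogen on an aromatic carbon gave a 1.1-fold lower number from compound 3 to compound 4 (0.05 log units; within the scatter), so compound 3 and compound 4 cannot be told apart. Set beside the earlier step, this shows that the change was tolerated on the core of compound 3, but not that it behaves alike on both cores: the same change on two cores in this assay, an at least 1.4-fold higher number (0.16 log units; that floor lies within the scatter) from compound 1 to compound 2 and a 1.1-fold lower number (0.05 log units; within the scatter) from compound 3 to compound 4; the limit leaves it open whether they differ The entry for compound 2 is a limit of the assay, not a number: the limit of > 10000 nM in this assay, at which 1 of the 4 values shown sits.

The compounds shown leave open how a chloro, a methyl or a nitrile at this same place on the core of compound 3 would read in this assay. They also leave open what a carboxylic acid in place of the amino group would do.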